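Lengthening the chain to the azepan-1-yl group

A few compounds are considered here, and "the series" means these few. Any claim that something is new, unique, unknown or untested is made for them only; others in the source may bear on it.

Compound 1 `CCCC(=O)c1ccc2c(c1)sc(=O)n2CCCN1CCCCCC1` gives 2.6 nM in an assay on cell membranes for displacement of a labelled ligand from Sigma non-opioid intracellular receptor 1 (Rattus norvegicus); on this read-out lower numbers stand for stronger inhibition and higher numbers for weaker inhibition. Compound 2 `CCCC(=O)c1ccc2c(c1)sc(=O)n2CCCCN1CCCCCC1` carries (azepan-1-yl)methyl in place of azepan-1-yl on a saturated chain carbon, three bonds along the chain from an aromatic nitrogen and gives 4.8 nM in this assay, the step being a 1.8-fold higher number from compound 1 to compound 2 (0.27 log units; within the scatter). Compound 3 `CCCc1ccc2c(c1)sc(=O)n2CCCCN1CCCCCC1` gives 6.1 nM in this assay, with a step of a 1.3-fold higher number from compound 2 to compound 3 (0.10 log units; within the scatter). The difference between the core of compound 3 and the core of compound 1 is not broken down here.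

Compound 4 `CCCc1ccc2c(c1)sc(=O)n2CCCCCN1CCCCCC1` has not been measured; it carries (azepan-1-yl)methyl in place of azepan-1-yl on a saturated chain carbon, four bonds along the chain from an aromatic nitrogen. Going by the values given here, this is the same kind of change as the one seen between compound 1 and compound 2, though the place is not identical: there the changed saturated chain carbon lies three bonds along the chain from an aromatic nitrogen, here four bonds along the chain from an aromatic nitrogen.

For compound 4 the expected step is a 1.6-fold higher number from compound 3 to compound 4 (0.21 log units; within the scatter). This expectation rests on the earlier step of a 1.8-fold higher number from compound 1 to compound 2 (0.27 log units; within the scatter) and on compound 3 giving 6.1 nM in this assay. Compound 4 is therefore estimated at 10 nM in this assay, with a range from 4 nM to 25 nM.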

Compound 4, inhibition constant: 4.6 nM
The estimate for compound 4 lay 2.2-fold (0.34 log units) above the measured number; the measured number falls inside the stated range.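

In this assay, placing (azepan-1-yl)methyl in place of azepan-1-yl on a saturated chain carbon, four bonds along the chain from an aromatic nitrogen, gives a 1.3-fold lower number from compound 3 to compound 4 (0.12 log units; within the scatter). Set beside the earlier case, the two steps do not differ beyond what repeated measurement allows: the same change on two cores in this assay, a 1.8-fold higher number (0.27 log units; within the scatter) from compound 1 to compound 2 and a 1.3-fold lower number (0.12 log units; within the scatter) from compound 3 to compound 4, 2.4-fold (0.39 log units) apart, within the scatter of two such steps. Going by these compounds alone, both steps are small enough that neither can be given a direction, so the two pairs show only that this change stayed within the scatter on both cores; they do not show a shared effect of a defined size, and with the cores and the chain place both differing, they do not show that the result would carry over to any further core.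

The compounds shown leave open how the number behaves with a chain longer than that of compound 4 or shorter than that of compound 1. They also leave open whether an open-chain amine such as diethylamino could replace azepan-1-yl on either core.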